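Working notes: from compound 2 to compound 3

A few compounds are considered here, and "the series" means these few. Any claim that something is new, unique, unknown or untested is made for them only; others in the source may bear on it.

Among the measured compounds shown here, in a functional assay on DU-145 cells (Homo sapiens) for inhibition, read by trypan blue exclusion, with a stated time of 96 h (on this read-out higher numbers stand for weaker inhibition of growth and lower numbers for stronger inhibition of growth), compound 2 (`Cc1cc(C)cc(/C=C(/SCc2ccc(Cl)cc2)C(=O)c2ccc(Cl)cc2)c1`) gives 10000 nM, the only exact number so far. Compound 1 (`O=C(/C(=C\c1c(O)cc(O)cc1O)SCc1ccc(Cl)cc1)c1ccc(Cl)cc1`) gives > 100000 nM, and this value is a limit of the assay. Compound 3 (`O=C(/C(=C\c1ccc(O)cc1)SCc1ccc(Cl)cc1)c1ccc(Cl)cc1`) is unmeasured and carries 4-hydroxyphenyl in place of 3,5-dimethylphenyl on a double-bonded chain carbon bound to a double-bonded chain carbon. For the measured compounds named here, one measured step bears on this change: an at least 10-fold lower number from compound 1 to compound 2 (1.00 log units; beyond the scatter), with 3,5-dimethylphenyl replacing 2,4,6-trihydroxyphenyl at the same place. The entering group restores a hydroxyl, so a partial return along that step is expected, towards a higher number in this assay and weaker inhibition of growth. This rests on one step only, so the expectation is loose. The estimated change is a 2.5-fold higher number from compound 2 to compound 3 (0.40 log units; beyond the scatter). The expected value for compound 3 is 25000 nM, with an estimated range of 6000 nM to 100000 nM.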

Compound 3, concentration for 50% growth inhibition: 10000 nM
The estimate for compound 3 lay 2.5-fold (0.40 log units) above the measured number; the measured number falls inside the stated range.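

In this assay there is no change at the digits printed from compound 2 to compound 3 (within the scatter) when 4-hydroxyphenyl replaces 3,5-dimethylphenyl on a double-bonded chain carbon bound to a double-bonded chain carbon, so a hydroxyl on this ring does not by itself raise the number. With 4-hydroxyphenyl in place of 2,4,6-trihydroxyphenyl there is an at least 10-fold lower number from compound 1 to compound 3 (1.00 log units; beyond the scatter), which ties the weak result to 2,4,6-trihydroxyphenyl as a whole rather than to the mere presence of a hydroxyl. Compound 1 gives > 100000 nM, which is a limit, so the size of this step is bounded on one side only: the limit of > 100000 nM in this assay, at which 1 of the 3 values shown sits.

From the compounds shown here alone, whether an aminophenyl or a carboxyphenyl group at this place would keep the number shared by compound 2 and compound 3 stays open. Also open, going by these compounds, is which of the hydroxyls of 2,4,6-trihydroxyphenyl carries the loss.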